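Swapping a hydroxyethyl-piperidine for an azepane ring

A few compounds are considered here, and "the series" means these few. Any claim that something is new, unique, unknown or untested is made for them only; others in the source may bear on it.

The two measured compounds share a sulfonamide-linked piperidine core. Compound 1 `CC1CCN(C2CCN(S(=O)(=O)c3cccc(-c4ccccc4C(F)(F)F)c3)CC2)CC1` is tested in a functional assay on DLD-1 cells (Homo sapiens) for antiproliferative activity, read by CellTiter-Glo, with a stated time of 72 h (on this read-out higher numbers stand for weaker inhibition and lower numbers for stronger inhibition), where compound 1 gives 10 nM. Compound 2 `Cc1cc(C)c(S(=O)(=O)N2CCC(N3CCC(CCO)CC3)CC2)c(C)c1` is measured in the same way, and compound 2 gives 19 nM. Of these two numbers, compound 2 carries the higher one, yet the gap to compound 1 lies within the usual scatter, so the two values cannot be told apart.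

Compound 3 `Cc1cc(C)c(S(=O)(=O)N2CCC(N3CCCCCC3)CC2)c(C)c1` is not yet measured. It differs from compound 2 in one place: azepan-1-yl in place of 4-(2-hydroxyethyl)piperidin-1-yl on a saturated ring carbon. Within the data shown here, no measured pair shows what this kind of swap does, so the direction rests on judgement alone. The expected step from compound 2 to compound 3 in this assay is a 1.6-fold higher number from compound 2 to compound 3 (0.20 log units; within the scatter), a small move toward a higher number that may not exceed the scatter. Compound 3 is estimated to give 30 nM, with a likely range from 10 nM to 100 nM.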

Compound 3, half-maximal inhibitory concentration: 5.3 nM
Compound 3: middle estimate off by 5.7-fold (0.75 log units), on the high side, and the stated range ends above it.
By their numbers in this assay, from the lowest: compounds 3, 1 and 2 (each within the scatter of the next, the first and the last beyond it).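

Among these compounds, this is the first measured change at this place, on a saturated ring carbon three ring bonds from the ring nitrogen, and in this assay it gives a 3.6-fold lower number from compound 2 to compound 3 (0.55 log units; beyond the scatter) and so moves beyond the scatter. The 4-(2-hydroxyethyl)piperidin-1-yl group, with its hydrogen-bond donor, is therefore not required for a low number here, since azepan-1-yl, which has no such donor and fewer heavy atoms, gives a lower one. No measurement shown here explains why this swap lowers the number.

The swap alters ring size and removes the hydroxyethyl chain together, so the compounds shown cannot tell which of the two changes produces the step. An unsubstituted piperidin-1-yl ring, or an azepan-1-yl ring carrying a 2-hydroxyethyl chain, would pull those two changes apart.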